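Chain length on the shared core of compound 2

The source may hold more compounds than are shown below. What is called first, only, known or untested is meant among the compounds shown, and "the series" means these compounds.

Measured so far:
compound 1, `CCCCC/C(=C\B1OC(C)(C)C(C)(C)O1)C(O)(c1ccccc1)C1CC1`: 10400 nM
compound 2, `CCC/C(=C\B1OC(C)(C)C(C)(C)O1)C(O)(c1ccccc1)C1CC1`: 55200 nM
compound 3, `CCC/C(=C\B1OC(C)(C)C(C)(C)O1)C(O)c1ccccc1`: "not active" (no number reported)

In a functional assay on ARH-77 cells (Homo sapiens) for cytotoxicity, read by MTT assay, with a stated time of 72 h (on this read-out higher numbers stand for weaker inhibition and lower numbers for stronger inhibition), compound 2 gives the highest of the two numbers reported, and its nearest neighbour is compound 1, with compound 3 reported without a number. Among the measured compounds shown here, the only one-place step that can be read is a 5.3-fold higher number from compound 1 to compound 2 (0.72 log units; beyond the scatter), which removes ethyl and weakens inhibition. Compound 4, `CCCCCCCC/C(=C\B1OC(C)(C)C(C)(C)O1)C(O)(c1ccccc1)C1CC1`, reverses that direction and goes further: pentyl in place of hydrogen on a saturated chain carbon, three bonds along the chain from a double-bonded chain carbon, the same difference cut one bond further out reading propyl to octyl. The step from compound 1 to compound 2 bears directly on this, and it was beyond the scatter; a longer chain is therefore expected to lower the number in this assay for compound 4 by at least a comparable amount, and the estimated step is a 16-fold lower number from compound 2 to compound 4 (1.20 log units; beyond the scatter). Compound 4 is estimated at 3500 nM in this assay, with a range from 900 nM to 15000 nM, because compound 1 with its longer chain gives 10400 nM and compound 4 extends the chain further still. The measured value follows.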

Compound 4, half-maximal inhibitory concentration: 6360 nM
Compound 4: the middle estimate sits 1.8-fold (0.26 log units) below what was measured; the range from low to high includes it.
By their numbers in this assay, from the lowest: compounds 4 and 1 (each within the scatter of the next); then compound 2.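

Pentyl in place of hydrogen on a saturated chain carbon, three bonds along the chain from a double-bonded chain carbon, gives an 8.7-fold lower number from compound 2 to compound 4 (0.94 log units; beyond the scatter) in this assay and so shows that a second, larger group at this position also lands beyond the scatter relative to compound 2. Propyl in place of hydrogen, five bonds along the chain from a double-bonded chain carbon, gives a 1.6-fold lower number from compound 1 to compound 4 (0.21 log units; within the scatter) and so shows that the further extension separates nothing that these numbers can resolve. No evidence is available on what lies behind these numbers.

Among the compounds shown here, compound 3 carries no number, so no step to it can be read. Going by these compounds, whether a longer chain, or an amine at the chain end, would shift the number beyond the scatter around compound 1 and compound 4 stays open.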